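From hydroxy to methoxy: what compound 4 may show

This account rests on a few compounds, and the source may have more. Where it says the series, first, only, none or still open, it means among the compounds named here.

- Compound 1 `O=C(/C=C/c1cccc(OCc2ccccc2)c1)c1ccc([N+](=O)[O-])cc1` gives 82400 nM
- Compound 2 `O=C(/C=C/c1cccc(OCc2ccccc2)c1)c1ccc(O)cc1` gives 8100 nM
- Compound 3 `O=C(/C=C/c1cccc(OCc2ccccc2)c1)c1ccccc1` gives 22000 nM

In an ADME assay on CHO cells (Cricetulus griseus) for cytotoxicity, read by MTT assay, with a stated time of 68 h (on this read-out lower numbers stand for stronger inhibition and higher numbers for weaker inhibition), compound 2 gives 8100 nM, the lowest of the three numbers. The three compounds differ only in one group on an aromatic carbon, and the hydroxy of compound 2 is the group that marks the low end. Compound 4 `COc1ccc(C(=O)/C=C/c2cccc(OCc3ccccc3)c2)cc1` has not yet been measured. It differs from compound 2 by methyl in place of hydrogen on an oxygen on an aromatic ring, which turns hydroxy into methoxy.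

Among the compounds with values here, no measured step makes this exact change, so the evidence is indirect. Removing the hydroxy altogether gave a 2.7-fold higher number from compound 2 to compound 3 (0.43 log units; beyond the scatter), a modest step. Hydroxy in place of nitro gave a 10-fold lower number from compound 1 to compound 2 (1.01 log units; beyond the scatter), a large one, while hydrogen in place of nitro gave a 3.7-fold lower number from compound 1 to compound 3 (0.57 log units; beyond the scatter), a modest one. Methoxy keeps the oxygen of compound 2 but loses its hydrogen, so compound 4 is expected to fall between compound 2 and compound 3 in this assay. The expected change is small, towards a higher number, and not clearly beyond the scatter: a 1.9-fold higher number from compound 2 to compound 4 (0.27 log units; within the scatter). For compound 4 the estimated value is 15000 nM, with an expected range from 6000 nM to 38000 nM.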

Compound 4, half-maximal inhibitory concentration: 22900 nM
Estimate against measurement, compound 4: 1.5-fold (0.18 log units) below; low and high end bracket the measured number.
By their numbers in this assay, from the lowest: compound 2; then compounds 3 and 4 (each within the scatter of the next); then compound 1.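

In this assay, within the data shown here, methyl in place of hydrogen on the oxygen gives a 2.8-fold higher number from compound 2 to compound 4 (0.45 log units; beyond the scatter) as a modest step, so keeping the oxygen on the aromatic ring does not keep the low number of compound 2, and the earlier compounds could not show this. Methoxy in place of hydrogen on the aromatic carbon gives a 1.0-fold higher number from compound 3 to compound 4 (0.02 log units; within the scatter) and so leaves compound 3 and compound 4 indistinguishable in this assay, which means that among these four compounds the low number goes with the free hydroxy alone and not with any oxygen at this place. Methoxy in place of nitro gives a 3.6-fold lower number from compound 1 to compound 4 (0.56 log units; beyond the scatter) as a modest step, and this puts the methoxy compound level with the unsubstituted compound 3 in its distance from the nitro compound.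

The compounds shown leave open whether another group with a hydrogen on the atom attached to the ring, such as an amine or a carboxylic acid, would reach the low number of compound 2, and whether a longer chain on the oxygen would stay level with methoxy. Nothing among the data shown explains why replacing that hydrogen moves the number as it does.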